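The compounds below may be only part of what the source reports. "The series", "measured", "known", "first", "only" and "open" are said of these compounds alone.

Working notes on the series. In a functional assay on MDA-MB-231 cells (Homo sapiens) for antiproliferative activity, read by MTT assay, with a stated time of 48 h (on this read-out lower numbers stand for stronger inhibition and higher numbers for weaker inhibition), compound 1 (`C=CS(=O)(=O)N1CCN(c2ncnc3sc(-c4ccccc4)cc23)CC1`) gives 54200 nM, and compound 2 (`COc1ccc(NC(=O)N2CCN(c3ncnc4sc(-c5ccc(N6CCN(C)CC6)cc5)cc34)CC2)cc1`) gives 20900 nM. Compound 2 holds the lower of the two numbers, and the gap between them lies beyond the usual scatter. Going by the values given here, the two compounds differ in more than one place, so the series offers no measured step that isolates one structural change.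

Compound 3 (`COc1ccccc1NC(=O)N1CCN(c2ncnc3sc(-c4ccc(N5CCN(C)CC5)cc4)cc23)CC1`) has not yet been measured. It has the same atoms as compound 2, joined differently: 2-methoxyphenyl in place of 4-methoxyphenyl on an amide-type nitrogen. In words, 2-methoxyphenyl stands in place of 4-methoxyphenyl on an amide-type nitrogen.

Among the compounds with values here, no measured pair shows the effect of this exchange, so the expectation starts from compound 2 at 20900 nM. No step beyond the scatter is expected in this assay, in either direction. The expected change is a 1.1-fold higher number from compound 2 to compound 3 (0.02 log units; within the scatter), and this estimate stays within the scatter. For compound 3 the estimated value is 22000 nM, with an expected range of 9000 nM to 52000 nM.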

Compound 3, half-maximal inhibitory concentration: 23200 nM
Compound 3: middle estimate off by 1.1-fold (0.02 log units), on the low side; low and high end bracket the measured number.
By their numbers in this assay, from the lowest: compounds 2 and 3 (each within the scatter of the next); then compound 1.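

In this assay, going by these compounds alone, 2-methoxyphenyl in place of 4-methoxyphenyl on an amide-type nitrogen gives a 1.1-fold higher number from compound 2 to compound 3 (0.05 log units; within the scatter), the only measured step that isolates a single structural change. At this place, then, the read-out does not separate the two methoxyphenyl groups, which match in heavy atoms, aromatic ring and hydrogen-bond counts and differ only in how they are joined. No measurement shown here speaks to the reason for this result.

From the compounds shown here alone, the step covers only an exchange between these two methoxyphenyl groups, so it remains open whether a different group on the same phenyl ring, such as an amine, a carboxylic acid or a longer chain in place of methoxy, would move the number beyond the scatter. Compound 1 differs from compound 2 and compound 3 in more than one place, so the compounds shown also leave open which structural difference goes with the gap between compound 1 and the other two.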